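Swapping chloro for fluoro in a series at the assay limit

The source may hold more compounds than are shown below. What is called first, only, known or untested is meant among the compounds shown, and "the series" means these compounds.

Compound 1 `Clc1cccc(-c2n[nH]cc2N2CCNCC2)c1` carries a chloro group on a six-membered aromatic ring of carbon only. In an assay on isolated protein for binding affinity to 5-hydroxytryptamine receptor 1E (Homo sapiens) (a higher number here means a weaker inhibitor, a lower number a stronger inhibitor), compound 1 gives > 10000 nM, which is a limit of the assay and not a number. Compound 3 `Fc1cccc(-c2n[nH]cc2N2CCNCC2)c1` differs from compound 1 by fluoro in place of chloro on an aromatic carbon. In this assay compound 3 gives > 10000 nM, again a limit. The step that the two limits leave unreadable from compound 1 to compound 3 cannot be read because of the limit of > 10000 nM in this assay, at which 3 of the 3 values shown sit. Compound 2 `Clc1ccc(-c2n[nH]cc2N2CCNCC2)cc1` has the same atoms as compound 1, joined differently; the difference between the two cores is not broken down here. In this assay compound 2 gives > 10000 nM, once more a limit rather than a number. Compound 4 `Fc1ccc(-c2n[nH]cc2N2CCNCC2)cc1` has not been measured; it differs from compound 2 by fluoro in place of chloro on an aromatic carbon. For the measured compounds named here, this is the same kind of change as the one made from compound 1 to compound 3, but not the same: there the substituent sits meta to a large group, here para to a large group. With both ends of the measured step resting at the limit, a step that the limit leaves unreadable from compound 2 to compound 4 is expected. Compound 4 is accordingly expected to give 15000 nM, within 5000 nM to 50000 nM, most likely reported only as a limit.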

Compound 4, inhibition constant: > 10000 nM
Compound 4: no number, only a limit; the forecaster's own chance of this, stated with the estimate: 85%; the middle value lies beyond the limit too.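

No new step can be read between compound 2 and compound 4, because both compounds rest at a limit and not at a number: the limit of > 10000 nM in this assay, at which 4 of the 4 values shown sit. The compounds shown leave open what actual number any of them would give, and so whether swapping chloro for fluoro changes the binding at all.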